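Trimming the long acyl chain of compound 2

A few compounds are considered here, and "the series" means these few. Any claim that something is new, unique, unknown or untested is made for them only; others in the source may bear on it.

Measured in a functional assay on MDA-MB-231 cells (Homo sapiens) for cytotoxicity, read by MTT assay, with a stated time of 24 h; a lower number here means a stronger inhibitor, a higher number a weaker inhibitor:
compound 1 `CCCCCCCC(=O)Nc1nnc(S[C@@H]2O[C@H](CO)[C@H](O)[C@H](O)[C@H]2O)s1` gives 30800 nM in this series
compound 2 `CCCCCCCCCCCCCCCC(=O)Nc1nnc(S[C@@H]2O[C@H](CO)[C@H](O)[C@H](O)[C@H]2O)s1` gives 62300 nM in this series

Compound 2 holds the higher of the two numbers, which makes it the weaker inhibitor of the pair. Compound 3 `CCCCCCCCCCCCCC(=O)Nc1nnc(S[C@@H]2O[C@H](CO)[C@H](O)[C@H](O)[C@H]2O)s1` carries hydrogen in place of ethyl on a saturated chain carbon, ten or more bonds along the chain from a carbonyl carbon.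

Within the data shown here, only one measured step bears on this change: a 2.0-fold higher number from compound 1 to compound 2 (0.31 log units; beyond the scatter), which came with octyl in place of hydrogen on the same chain. That step is modest, and the present change takes back only part of that chain. Two compounds cannot show whether the trend is smooth, so the expectation in this assay is a small move toward a lower number, probably within the scatter. An estimated 1.2-fold lower number from compound 2 to compound 3 (0.10 log units; within the scatter) is expected. For compound 3 the estimated value is 50000 nM (expected range 30000 nM to 85000 nM).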

Compound 3, half-maximal inhibitory concentration: 33300 nM
Compound 3: the middle estimate sits 1.5-fold (0.18 log units) above what was measured; the measured number falls inside the stated range.
By their numbers in this assay, from the lowest: compounds 1, 3 and 2 (each within the scatter of the next, the first and the last beyond it).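

In this assay the change of ethyl to hydrogen on a saturated chain carbon gives a 1.9-fold lower number from compound 2 to compound 3 (0.27 log units; within the scatter) and so stays inside the scatter. The comparison with the shorter chain gives a 1.1-fold higher number from compound 1 to compound 3 (0.03 log units; within the scatter) and also stays inside it, so compound 3 cannot be separated from either of the other two compounds. The gap between compound 1 and compound 2 remains the only one beyond the scatter, and it cannot be assigned to any single part of the chain. No supporting data on the origin of these values are available.

Still open, going by these compounds, is how a chain shorter than that of compound 1, or one longer than that of compound 2, would read. Equally open, on these data alone, is the effect of an amine or a carboxylic acid at the chain end.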